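A Sulfonyl Replacement on the Aniline Nitrogen and Cytotoxicity

The source may hold more compounds than are shown below. What is called first, only, known or untested is meant among the compounds shown, and "the series" means these compounds.

Compound 2 `COc1ccc([C@H]2CC(=O)N(c3cccc(NCC4CCOC4)c3)C2)cc1OC1CCCC1` shares its core with compound 1 `COc1ccc([C@H]2CC(=O)N(c3cccnc3)C2)cc1OC1CCCC1`. In a functional assay on HEK293 cells (Homo sapiens) for cytotoxicity (a higher number here means that more compound is tolerated, a lower number that less compound is tolerated), compound 1 gives > 10000 nM, which is a limit of the assay rather than a number. In this assay compound 2 likewise gives > 10000 nM, again a limit and not a number. Compound 2 therefore stands at the limit of > 10000 nM in this assay, at which 2 of the 2 values shown sit, and nothing separates the two known values. Compound 3 `COc1ccc([C@H]2CC(=O)N(c3cccc(NS(=O)(=O)c4cccc(Br)c4)c3)C2)cc1OC1CCCC1` is still to be measured in this assay. It differs from compound 2 by (3-bromophenyl)sulfonyl in place of (oxolan-3-yl)methyl on a nitrogen on an aromatic ring. Going by the values given here, no step between two measured compounds is known, so no measured change can point the direction. With both known values resting at the limit, the step is expected to be small or none beyond the scatter, which is what a number no higher from compound 2 to compound 3 (the limit leaves the size open) means. On that basis compound 3 is estimated at 10000 nM, within the range 4000 nM to 25000 nM.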

Compound 3, half-maximal cytotoxic concentration: > 10000 nM
Compound 3: a limit, no number; the forecaster's own chance of this, stated with the estimate: 65%; the middle value sits exactly at the limit.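

Going by these compounds alone, compound 2 and compound 3 both rest at a limit rather than at a number, and no step between them can be read. The compounds shown leave open what numbers compound 1, compound 2 and compound 3 would give in this assay, and whether exchanging (oxolan-3-yl)methyl for (3-bromophenyl)sulfonyl changes anything there.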